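The source may report more compounds than this note shows. Statements on the series, on what has been measured and on what is new or still open speak of the compounds shown alone.

In a functional assay on the whole organism for antagonist activity, with Mus musculus as the target (on this read-out lower numbers stand for an effect already at smaller amounts and higher numbers for an effect only at larger amounts of compound), compound 1 `COc1cc(N)c(Cl)cc1NC(=O)C1CCN(Cc2ccccc2Cl)CC1` gives only a limit, > 4 mg/kg, so its true number is not pinned down. Compound 2 `COc1cc(N)c(Cl)cc1NC(=O)C1CCN(Cc2ccc(F)cc2)CC1` gives 0.6 mg/kg in this assay. Compound 3 `COc1cc(N)c(Cl)cc1NC(=O)C1CCN(Cc2ccccc2F)CC1` also gives only a limit in this assay, > 4 mg/kg. Two of the three values thus sit at the limit of > 4 mg/kg in this assay, at which 2 of the 3 values shown sit, which is why the step from compound 1 to compound 3 cannot be read: a step that the two limits leave unreadable from compound 1 to compound 3. The two readable steps are an at least 6.6-fold lower number from compound 1 to compound 2 (0.82 log units; beyond the scatter) and an at least 6.6-fold higher number from compound 2 to compound 3 (0.82 log units; beyond the scatter); each turns on the ring carried on a saturated chain carbon bound to an amine nitrogen in a ring, and each is beyond the scatter.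

Compound 4 `COc1cc(N)c(Cl)cc1NC(=O)C1CCN(Cc2ccsc2)CC1` has not yet been measured. It differs from compound 1 at exactly that place: thiophen-3-yl in place of 2-chlorophenyl on a saturated chain carbon bound to an amine nitrogen in a ring. Compound 1 and compound 3 carry 2-chlorophenyl or 2-fluorophenyl there, and each of the two stays at a limit in this assay. Compound 2, which carries 4-fluorophenyl, reaches 0.6 mg/kg. Thiophen-3-yl carries no such halogen, so the expected direction is the one compound 2 showed. For compound 4 the expected value in this assay is 1.2 mg/kg, estimated to lie between 0.3 mg/kg and 4 mg/kg. This corresponds to an expected step of an at least 3.3-fold lower number from compound 1 to compound 4 (0.52 log units; beyond the scatter).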

Compound 4, dose for half-maximal effect: 3.4 mg/kg
Estimate against measurement, compound 4: 2.8-fold (0.45 log units) below, within the range that was stated.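

In this assay, among these compounds, moving to thiophen-3-yl on a saturated chain carbon bound to an amine nitrogen in a ring gives a 5.7-fold higher number from compound 2 to compound 4 (0.75 log units; beyond the scatter), so a ring without a halogen does not by itself match the 4-fluorophenyl group, a point the earlier compounds could not settle. Replacing 2-chlorophenyl gives an at least 1.1-fold lower number from compound 1 to compound 4 (0.07 log units; that floor lies within the scatter), and replacing 2-fluorophenyl gives an at least 1.1-fold lower number from compound 3 to compound 4 (0.07 log units; that floor lies within the scatter), so neither floor shows thiophen-3-yl to be better than the group it replaces. The true size of these two steps stays unknown because the values they start from are limits, not numbers: the limit of > 4 mg/kg in this assay, at which 2 of the 4 values shown sit.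

On these data alone, whether a plain phenyl or a 4-chlorophenyl group at this place would come as low as compound 2 remains open, and with it whether the fluoro group itself matters or only its place on the ring. Also open, as far as these compounds go, is how thiophen-2-yl or pyridin-3-yl would compare with the thiophen-3-yl of compound 4, which would show whether the way the five-membered ring is attached, or the kind of ring, shapes the result.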